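Removing aryl substituents in a kinase inhibitor series

The compounds below may be only part of what the source reports. "The series", "measured", "known", "first", "only" and "open" are said of these compounds alone.

Of the compounds shown here, three built on one shared core have been tested in an assay on isolated protein for inhibition of Rho-associated protein kinase 2 (Homo sapiens), read by a luciferase reporter; on this read-out lower numbers stand for stronger inhibition and higher numbers for weaker inhibition. Compound 1 `O=C(Nc1cc2cc[nH]c(=O)c2cc1Cl)C1CNCC1c1ccccn1` gives 14 nM. Compound 2 `CC(C)c1cccc(C2CNCC2C(=O)Nc2cc3cc[nH]c(=O)c3cc2Cl)c1` gives 6 nM, and compound 3 `O=C(Nc1cc2cc[nH]c(=O)c2cc1Cl)C1CNCC1c1ccc(Cl)cc1Cl` gives 8 nM. Exchanging pyridin-2-yl for 3-isopropylphenyl on a saturated ring carbon brought a 2.3-fold lower number from compound 1 to compound 2 (0.37 log units; beyond the scatter), whereas the corresponding exchange to 2,4-dichlorophenyl gave a 1.8-fold lower number from compound 1 to compound 3 (0.24 log units; within the scatter); between the two substituted phenyls the difference is a 1.3-fold higher number from compound 2 to compound 3 (0.12 log units; within the scatter). Compound 3 thus holds the second highest of the three numbers, nearest to compound 2 and furthest from compound 1, both gaps within the scatter.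

Compound 4 `O=C(Nc1cc2cc[nH]c(=O)c2cc1Cl)C1CNCC1c1ccccc1` has not yet been measured in this assay. It differs from compound 3 in one place: phenyl in place of 2,4-dichlorophenyl on a saturated ring carbon. Among the measured compounds shown here, the three aryl exchanges on that ring carbon are the steps that bear on this change, and they moved the read-out only modestly, one beyond and two within the scatter. For the measured compounds named here, compound 4 carries an unsubstituted phenyl, which none of the measured compounds has, so the expected step is a 1.5-fold higher number from compound 3 to compound 4 (0.18 log units; within the scatter), a small shift toward a higher number. Compound 4 is therefore estimated at 12 nM, with a range from 5 nM to 30 nM.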

Compound 4, half-maximal inhibitory concentration: 6 nM
Compound 4: middle estimate off by 2.0-fold (0.30 log units), on the high side; the measured number falls inside the stated range.
By their numbers in this assay, from the lowest: compounds 2, 4, 3 and 1 (each within the scatter of the next, the first and the last beyond it).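

In this assay, cutting the aryl group on this saturated ring carbon back to plain phenyl leaves the read-out within the scatter, both for the loss of the two chlorines, with a 1.3-fold lower number from compound 3 to compound 4 (0.12 log units; within the scatter), and for the loss of the isopropyl, with no change at the digits printed from compound 2 to compound 4 (within the scatter). Among the compounds shown here, neither of these substituents is therefore required at this position, a point the earlier compounds could not settle because all of them carried either a substituted phenyl or a pyridin-2-yl. The unsubstituted ring also shows that exchanging pyridin-2-yl for a carbon-only aromatic ring can by itself give a 2.3-fold lower number from compound 1 to compound 4 (0.37 log units; beyond the scatter), although compound 3 goes against any general rule, since its step stays within the scatter at a 1.8-fold lower number from compound 1 to compound 3 (0.24 log units; within the scatter). Nothing given here accounts for this flat response.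

The compounds shown leave open whether a group of another kind on the phenyl, such as a carboxylic acid, an aminomethyl or a longer alkyl chain, would move the read-out further than the isopropyl or the chlorines did. They also leave open whether pyridin-3-yl or pyridin-4-yl would stand with compound 1 or with compound 4.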